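This account rests on a few compounds, and the source may have more. Where it says the series, first, only, none or still open, it means among the compounds named here.

In a functional assay on MCF7 cells (Homo sapiens) for antiproliferative activity, read by MTT assay, with a stated time of 72 h (a lower number here means a stronger inhibitor, a higher number a weaker inhibitor), compound 1 `O=C1COc2ccc(-c3cccc(NS(=O)(=O)c4ccc(F)cc4)c3)cc2N1` gives 18300 nM. Compound 2 `CC(C)N1C(=O)COc2ccc(-c3cccc(NS(=O)(=O)c4ccc(F)cc4)c3)cc21`, which carries isopropyl on the amide-type nitrogen in a ring, gives 26000 nM, and the measured step is a 1.4-fold higher number from compound 1 to compound 2 (0.15 log units; within the scatter). Compound 3 `O=C1COc2ccc(-c3cccc(NS(=O)(=O)c4ccc(F)cc4)c3)cc2N1c1ccccc1`, with phenyl on that nitrogen, is recorded only as a limit, > 40000 nM. Its true value is therefore unknown, and the two steps leading to it are also bounded: an at least 2.1-fold higher number from compound 1 to compound 3 (0.33 log units; beyond the scatter) and an at least 1.5-fold higher number from compound 2 to compound 3 (0.18 log units; that floor lies within the scatter).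

Compound 4 `Cc1ccc(N2C(=O)COc3ccc(-c4cccc(NS(=O)(=O)c5ccc(F)cc5)c4)cc32)cc1` turns that phenyl into 4-methylphenyl: methyl in place of hydrogen on an aromatic carbon. Within the data shown here, no measured step tests a methyl on this phenyl. The closest evidence is the set of changes on the nitrogen, such as a 1.4-fold higher number from compound 1 to compound 2 (0.15 log units; within the scatter) for compound 2, and none of them gave a lower number beyond the scatter. The expected change is therefore none beyond the scatter, and the estimate is a number no higher from compound 3 to compound 4 (the limit leaves the size open), with another limit quite possible. For compound 4, the expected value is 40000 nM, within an estimated range from 18000 nM to 80000 nM.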

Compound 4, half-maximal inhibitory concentration: 32100 nM
Beside the measured number, compound 4's estimate is 1.2-fold (0.10 log units) above it, within the range that was stated.
By their numbers in this assay, from the lowest: compounds 1, 2 and 4 (each within the scatter of the next). At a limit, above all of these: compound 3.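

In this assay, compound 4 puts a substituted phenyl on the ring nitrogen and returns a measured number, which compound 3, with plain phenyl, did not. The two measured steps are a 1.8-fold higher number from compound 1 to compound 4 (0.24 log units; within the scatter) and a 1.2-fold higher number from compound 2 to compound 4 (0.09 log units; within the scatter), so 4-methylphenyl on this nitrogen cannot be told apart from isopropyl or hydrogen here. On these data alone, the effect of the methyl itself can be read only as a floor, an at least 1.2-fold lower number from compound 3 to compound 4 (0.09 log units; that floor lies within the scatter), and its true size stays unknown because the plain phenyl compound is recorded only as a limit: the limit of > 40000 nM in this assay, at which 1 of the 4 values shown sits.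

Whether the methyl changes anything therefore remains undecided. The compounds shown also leave open how an amine or a carboxylic acid on this phenyl would read, and whether a longer chain on the ring nitrogen would read differently from isopropyl.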